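The compounds below may be only part of what the source reports. "The series", "measured", "known", "first", "only" and "open" are said of these compounds alone.

Two compounds carry a number in a functional assay on MCF7 cells (Homo sapiens) for cytotoxicity, read by MTT assay, with a stated time of 48 h; on this read-out higher numbers stand for weaker inhibition and lower numbers for stronger inhibition. Compound 1 `COc1ccc(-c2ocnc2-c2cc(Br)c(OC)c(OC)c2)cc1OC` gives 6100 nM there, the higher of the two numbers. For the measured compounds named here, compound 2 `COc1ccc(-c2c(-c3cc(OC)c(SC)c(OC)c3)ncn2C)cc1O`, built on a different core, gives 1630 nM in this assay, and the two values stand beyond the scatter from each other; no one-point step connects them. Compound 3 `COc1ccc(-c2ocnc2-c2cc(Br)c(OC)c(OC)c2)cc1SC` is the next compound to be measured in this assay. It arises from compound 1 by a single change: methylsulfanyl in place of methoxy on an aromatic carbon, at a position ortho to a methoxy group on the six-membered aromatic ring of carbon only. Going by the values given here, none of the measured compounds isolates this swap, so the move from compound 1 to compound 3 has no direct precedent here. The expected step of a 1.7-fold lower number from compound 1 to compound 3 (0.24 log units; within the scatter) is a modest move toward a lower number, close to the edge of the scatter. Compound 3 is accordingly estimated at 3500 nM, within a range from 1200 nM to 10000 nM.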

Compound 3, half-maximal inhibitory concentration: 2780 nM
Compound 3: the middle estimate sits 1.3-fold (0.10 log units) above what was measured, and the stated range covers the measured number.
By their numbers in this assay, from the lowest: compounds 2 and 3 (each within the scatter of the next); then compound 1.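

In this assay, for the compounds shown here, methylsulfanyl in place of methoxy on this aromatic carbon, ortho to a methoxy group and meta to a large group, gives a 2.2-fold lower number from compound 1 to compound 3 (0.34 log units; beyond the scatter) as the first one-point step. This is a modest step beyond the scatter, so this position responds to the exchange of oxygen for sulfur in the group, and activity on this read-out is kept rather than lost. Nothing measured on these compounds bears on the reason for the step.

As far as these compounds go, whether a longer chain such as ethylsulfanyl, or an amine, at this position would move the number further remains open. The compounds shown also leave open whether the same swap gives a step of similar size on another core.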